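The source may hold more compounds than are shown below. What is called first, only, known or untested is meant among the compounds shown, and "the series" means these compounds.

The measured compounds:
Compound 1, `Nc1ccc(C(=O)/C=C/c2ccc(O)c(F)c2)cc1-c1ccc(F)cc1`: 31700 nM in a functional assay on SW480 cells (Homo sapiens) for cytotoxicity, read by sulforhodamine B assay, with a stated time of 48 h; on this read-out higher numbers stand for weaker inhibition and lower numbers for stronger inhibition.
Compound 2, `COc1ccc(/C=C/C(=O)c2cccc(-c3cccc(F)c3)c2)cc1O`: "not determined" (no result reported) in this assay.

Within the data shown here, compound 1 is the only compound with a number in this assay; compound 2 carries no result there, so compound 1 stands alone and cannot be ranked against anything. Compound 3, `COc1cc(/C=C/C(=O)c2ccc(N)c(-c3ccc(F)cc3)c2)ccc1O`, differs from compound 1 in a single place: methoxy in place of fluoro on an aromatic carbon. Among the measured compounds shown here, no pair of measured compounds shows the effect of such a change, so the size of the step can only be estimated from the change itself. The account expects the step from compound 1 to compound 3 to be a 1.3-fold lower number from compound 1 to compound 3 (0.10 log units; within the scatter), a shift no larger than the usual scatter of repeated measurements in this assay and with no firm direction. For compound 3 the estimate in this assay is therefore 25000 nM, with a range from 8000 nM to 80000 nM.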

Compound 3, half-maximal inhibitory concentration: 8350 nM
Compound 3: the middle estimate sits 3.0-fold (0.48 log units) above what was measured; the measured number falls inside the stated range.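

In this assay, among these compounds, replacing 3-fluoro-4-hydroxyphenyl with 4-hydroxy-3-methoxyphenyl gives a 3.8-fold lower number from compound 1 to compound 3 (0.58 log units; beyond the scatter) and provides the first single-place comparison among the compounds with numbers. It shows that the group ortho to a hydroxy group matters in this assay, with methoxy at that place giving the lower number and therefore the stronger inhibition of this pair. No measured evidence bears on the reason for this step, so it stands as an observation only.

This single pair does not show whether the step comes with the added oxygen, the added carbon or the loss of fluoro. The compounds shown also leave open how an ethoxy group, a chlorine atom or plain hydrogen at this place would compare with methoxy and fluoro on the same core.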